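From 2-Chlorobenzyl to 4-Fluorobenzyl: an Expected Outcome

The compounds below may be only part of what the source reports. "The series", "measured", "known", "first", "only" and "open" are said of these compounds alone.

Of the compounds shown here, three sharing one core have been tested in a functional assay on the whole organism (artery, strain albino) with Rattus norvegicus as the target, with a stated time of 720 min, at a dose of 10 mg/kg by the oral route; a higher number here means more inhibition at the dose given (going by the name of the read-out), a lower number less inhibition. Compound 1 `COc1ccc(C2N=C(SCc3cccc(Cl)c3)NC(C)=C2C(=O)Nc2ccc(F)cc2)cc1OC` gives 15.5%. Compound 2 `CC1=C(C(=O)Nc2ccc(Br)cc2)C(c2ccc(Cl)cc2Cl)N=C(SCc2ccccc2Cl)N1` gives 20.6%. Compound 3 `COc1ccc(C2N=C(SCc3ccccc3Cl)NC(C)=C2C(=O)Nc2ccc(Br)cc2)cc1` gives 10.8%. Compound 3 has the smallest of the three numbers, yet its gap to compound 1 and its gap to compound 2 both lie within the scatter, so the three cannot be told apart on these data. Among the compounds with values here, the only single-point step measured, a number 9.8 percentage points lower from compound 2 to compound 3 (within the scatter), stays within the scatter as well.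

Compound 4 `COc1ccc(C2N=C(SCc3ccc(F)cc3)NC(C)=C2C(=O)Nc2ccc(Br)cc2)cc1` differs from compound 3 in one place: 4-fluorophenyl in place of 2-chlorophenyl on a saturated chain carbon bound to a sulfur. Within the data shown here, no measured pair differs only in this way, so no step speaks to it directly. Compound 1 carries a 3-chlorophenyl at that same place but also differs elsewhere, and its value and that of compound 3 lie within the scatter of each other. With every recorded step this small, the step from compound 3 to compound 4 in this assay is expected to be a number 1.2 percentage points higher from compound 3 to compound 4 (within the scatter), a change not beyond the scatter. Compound 4 is therefore estimated to give 12%, within a range from 3% to 25%.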

Compound 4, a percentage reported as inhibition, in the whole organism at one dose (the size of the read-out at that dose, not a potency): 19.1%
The estimate for compound 4 lay 7.1 percentage points below the measured number; the range from low to high includes it.
By their numbers in this assay, from the lowest: compounds 3, 1, 4 and 2 (each within the scatter of the next).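

Within the data shown here, this pair is the first in which the group on the saturated chain carbon bound to a sulfur changes while the rest of the molecule stays the same. Compound 1 also carries a different group there, but it differs elsewhere too, so it could not isolate this position. In this assay, 4-fluorophenyl in place of 2-chlorophenyl gives a number 8.3 percentage points higher from compound 3 to compound 4 (within the scatter), so this exchange of one halogen-bearing phenyl ring for another has no effect that can be told apart from ordinary variation between repeated measurements. Nothing available here offers an explanation for the size of this step.

Among these compounds, all the groups seen at this position so far are halogen-substituted benzyl groups, so it remains open whether a more different group on the sulfur, such as a plain methyl, a longer chain like 2-phenylethyl, or a benzyl ring carrying an amine or a carboxylic acid, would produce a step beyond the scatter. Going by these compounds, it is also open whether the exchange of 2-chlorobenzyl for 4-fluorobenzyl would give a similar step on a compound with a different group elsewhere on the shared core.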